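A few compounds are considered here, and "the series" means these few. Any claim that something is new, unique, unknown or untested is made for them only; others in the source may bear on it.

Among the measured compounds shown here, in a functional assay on SMMC-7721 cells (Homo sapiens) for antiproliferative activity, read by CCK-8 assay, with a stated time of 72 h (a lower number here means a stronger inhibitor, a higher number a weaker inhibitor), compound 1 (`Nc1ccccc1NC(=O)c1ccc(CSc2cccc(F)c2)cc1`) gives 3280 nM as the only number so far. Going by these compounds, compound 2 (`Nc1ccccc1NC(=O)/C=C/c1ccc(CSc2ccc(F)cc2)cc1`) has no number to stand on: its entry reads "not determined" (no result reported) with no result reported, and its place on the scale is unknown.

Compound 3 (`Nc1ccccc1NC(=O)/C=C/c1ccc(CSCCc2ccccc2)cc1`) has phenethyl in place of 4-fluorophenyl on a sulfur when set against compound 2. The sulfur's other neighbour, a saturated chain carbon, stays as it is. Each group carries a six-membered aromatic ring of carbon only, and the fluorine leaves with the 4-fluorophenyl.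

For the measured compounds named here, no measured step shows how such a swap behaves in this assay, and compound 2 offers no starting value. Going by the values given here, the expectation is a step no larger than the usual scatter of repeated measurements, with no direction favoured, around the one available number, that of compound 1 at 3280 nM in the same series. With so little to go on, the range has to stay wide. For compound 3 the expected value is 2500 nM with an estimated range from 800 nM to 8000 nM on this evidence.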

Compound 3, half-maximal inhibitory concentration: 10900 nM
Beside the measured number, compound 3's estimate is 4.4-fold (0.64 log units) below it, outside the stated range (above it).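

No step can be read between compound 2 and compound 3: in this assay compound 3 gives 10900 nM while compound 2 has no number to set against it. The compounds shown leave open what exchanging 4-fluorophenyl for phenethyl on the sulfur does to activity. No other data shown here bear on this result.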